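From Chloro to Trifluoromethyl: Oral Bioavailability Outlook

A few compounds are considered here, and "the series" means these few. Any claim that something is new, unique, unknown or untested is made for them only; others in the source may bear on it.

Compound 1 `Cn1c(CN2C[C@@H]3C(COc4ccccc4)[C@@H]3C2)nc2ccccc21`: < 2%
Compound 2 `Cn1c(CN2C[C@@H]3C(COc4ccc(Cl)cn4)[C@@H]3C2)nc2ccccc21`: 20%
Compound 3 `Cn1c(CN2C[C@@H]3C(COc4ccc(C(F)(F)F)cn4)[C@@H]3C2)nc2ccccc21`: to be measured

In an in vivo ADME assay on the whole organism (strain Sprague-Dawley) for pharmacokinetics, with Rattus norvegicus as the target, at a dose of 5 mg/kg by the oral route (on this read-out lower numbers stand for lower oral bioavailability and higher numbers for higher oral bioavailability), compound 1 gives < 2%, which is a limit of the assay and not a number. Compound 2 gives 20% in this assay, the only number shown. Within the data shown here, the single measured step is a number at least 18 percentage points higher from compound 1 to compound 2 (beyond the scatter), brought about by 5-chloropyridin-2-yl in place of phenyl on an oxygen on a saturated carbon, and it starts from the limit of < 2% in this assay, at which 1 of the 2 values shown sits, so only its lower bound is known.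

Compound 3 `Cn1c(CN2C[C@@H]3C(COc4ccc(C(F)(F)F)cn4)[C@@H]3C2)nc2ccccc21` differs from compound 2 by trifluoromethyl in place of chloro on an aromatic carbon. Among the measured compounds shown here, no measured step bears on this exchange: the one step in hand concerns the swap of the whole aromatic ring, not the group on it. With nothing to point either way, the expectation for compound 3 is no step beyond the scatter, no change at the digits printed from compound 2 to compound 3 (within the scatter). Compound 3 is therefore estimated at 20%, with a range from 6% to 40% in this assay.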

Compound 3, oral bioavailability: 27%
Compound 3: middle estimate off by 7 percentage points, on the low side; the range from low to high includes it.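

In this assay, among these compounds, this result gives the first reading at this place, on an aromatic carbon of a six-membered aromatic ring with 1 nitrogen, para to a large group: a number 7 percentage points higher from compound 2 to compound 3 (within the scatter) follows from trifluoromethyl in place of chloro. The earlier compounds shown here showed only what the exchange of the whole aromatic ring did, whereas this pair keeps that ring and changes only the group on it. Chloro and trifluoromethyl cannot be told apart here on oral bioavailability, although the entering group is larger than the one that leaves. Nothing at hand explains why these two groups read alike in this assay.

As far as these compounds go, it remains open whether a different group at this place, such as an amine, a carboxylic acid or a methoxy group, would shift oral bioavailability beyond the scatter. From the compounds shown here alone, it is also open whether chloro and trifluoromethyl would read alike if placed on the phenyl ring of compound 1, or at another carbon of the pyridine-type ring shared by compound 2 and compound 3.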